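The compounds below may be only part of what the source reports. "The series", "measured", "known", "first", "only" and "open" are said of these compounds alone.

Measured so far in a functional assay on MCF7 cells (Homo sapiens) for inhibition, read by sulforhodamine B assay; on this read-out lower numbers stand for stronger inhibition of growth and higher numbers for weaker inhibition of growth 
Compound 1 `N#CC1=C(N)OC2=C(C(=O)c3ccccc32)C12C(=O)Nc1ccc(Br)cc12` gives > 100000 nM as a limit of the assay
Compound 2 `N#CC1=C(N)OC2=C(C(=O)c3ccccc32)C12C(=O)Nc1ccc(F)cc12` gives 90900 nM as a true number

Among the compounds with values here, compound 2 holds the only true number here, and it sits close to that limit. Compound 3 `N#CC1=C(N)OC2=C(C(=O)c3ccccc32)C12C(=O)Nc1ccc(I)cc12` carries one change, iodo in place of fluoro on an aromatic carbon with iodo in place of fluoro on an aromatic carbon. Within the data shown here, the one measured step that bears on this is an at least 1.1-fold lower number from compound 1 to compound 2 (0.04 log units; that floor lies within the scatter) for fluoro in place of bromo, which rests on the limit of > 100000 nM in this assay, at which 1 of the 2 values shown sits, and stays within the scatter. No step beyond the scatter is therefore expected in this assay and the expected change is a 1.1-fold higher number from compound 2 to compound 3 (0.04 log units; within the scatter) in size. Compound 3 is estimated at 100000 nM with an expected range from 50000 nM to 200000 nM overall.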

Compound 3, concentration for 50% growth inhibition: 62000 nM
Beside the measured number, compound 3's estimate is 1.6-fold (0.21 log units) above it; measured number inside the range.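

Iodo gives a second true number at this position, and replacing fluoro with it in this assay produces only a 1.5-fold lower number from compound 2 to compound 3 (0.17 log units; within the scatter), so these two halogens cannot be told apart here. The comparison with bromo gives an at least 1.6-fold lower number from compound 1 to compound 3 (0.20 log units; that floor lies within the scatter), but this is only a floor, so its full size stays unknown: the limit of > 100000 nM in this assay, at which 1 of the 3 values shown sits.

From the compounds shown here alone, it remains open whether a group other than a halogen, such as an amine or a carboxylic acid, on this same aromatic carbon would shift the number beyond the scatter.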